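A few compounds are considered here, and "the series" means these few. Any claim that something is new, unique, unknown or untested is made for them only; others in the source may bear on it.

In a functional assay on HeLa cells (Homo sapiens) for antiproliferative activity, read by sulforhodamine B assay, with a stated time of 48 h (on this read-out lower numbers stand for stronger inhibition of growth and higher numbers for weaker inhibition of growth), compound 2 (`Cc1ccc(-c2nnc(C3=C(Cl)c4ccccc4CCC3)o2)cc1`) stands lowest of the three measured at 79 nM against compound 3 (`O=[N+]([O-])c1ccc(-c2nnc(C3=C(Cl)c4ccccc4CCC3)o2)cc1`) at 1320 nM and compound 1 (`ClC1=C(c2nnc(-c3ccccc3)o2)CCCc2ccccc21`) at 3220 nM on the same read-out. Compound 4 (`ClC1=C(c2nnc(-c3cccc(I)c3)o2)CCCc2ccccc21`) is unmeasured and carries 3-iodophenyl in place of 4-methylphenyl on an aromatic carbon. The large step for methyl (a 41-fold lower number from compound 1 to compound 2 (1.61 log units; beyond the scatter)) and the large step for nitro replacing methyl (a 17-fold higher number from compound 2 to compound 3 (1.22 log units; beyond the scatter)) show how far the number moves around compound 2, while the modest step for nitro (a 2.4-fold lower number from compound 1 to compound 3 (0.39 log units; beyond the scatter)) stays smaller. Going by the values given here, no measured compound carries iodine, so a moderate step to a higher number is expected in this assay when the methyl is lost. Compound 4 is estimated at 350 nM with an expected range of 70 nM to 1800 nM in this assay. That estimate means an expected 4.4-fold higher number from compound 2 to compound 4 (0.65 log units; beyond the scatter) on this read-out.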

Compound 4, concentration for 50% growth inhibition: 4100 nM
Compound 4: the middle estimate sits 12-fold (1.07 log units) below what was measured; measured number above the stated range.
By their numbers in this assay, from the lowest: compound 2; then compound 3; then compounds 1 and 4 (each within the scatter of the next).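

In this assay, the change to 3-iodophenyl gives a 52-fold higher number from compound 2 to compound 4 (1.72 log units; beyond the scatter), so the low number of compound 2 does not survive this swap. Iodo in place of hydrogen gives a 1.3-fold higher number from compound 1 to compound 4 (0.10 log units; within the scatter), so unlike methyl and nitro, this substituent leaves compound 4 indistinguishable from compound 1. Nothing available explains this result.

The compounds shown do not separate the effect of iodine from that of its place on the phenyl ring. On these data alone, how a 3-methylphenyl group, a 4-iodophenyl group or an amine on that ring would stand remains open.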